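The compounds below may be only part of what the source reports. "The series", "measured", "known", "first", "only" and "open" are said of these compounds alone.

Measured so far:

Compound 1 `O=C(Nc1ccc(F)cc1F)c1cc(Br)ccc1O`, in an ADME assay on RAW264.7 cells (Mus musculus) for cytotoxicity, read by MTT assay, with a stated time of 24 h (a higher number here means that more compound is tolerated, a lower number that less compound is tolerated), compound 1 gives 13800 nM.
Compound 2 `O=C(Nc1ccc(Cl)cc1F)c1cc(F)ccc1O`, in this assay compound 2 gives 7700 nM.
Compound 3 `O=C(Nc1ccc(I)cc1F)c1cc(Br)ccc1O`, in this assay compound 3 gives 6400 nM.

Compound 4 `O=C(Nc1ccc(Cl)cc1F)c1cc(I)ccc1O` has not yet been measured in this assay. It differs from compound 2 in one place: iodo in place of fluoro on an aromatic carbon. The same kind of change has already been made once among the measured compounds, from compound 1 to compound 3: iodo in place of fluoro on an aromatic carbon. That step gave a 2.2-fold lower number from compound 1 to compound 3 (0.33 log units; beyond the scatter). The two places are not the same, however. In compound 1 the exchanged group sits meta to a fluoro group and para to a large group, while in compound 2 it sits meta to a large group and para to a hydroxy group, so the change is of the same kind rather than the same. How the core of compound 1 differs from the core of compound 2 is not broken down here.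

Among the three measured compounds, compound 2 stands close to compound 3 and also within the usual scatter of compound 1, so no order among the three can be claimed.

Resting on the one comparable step, from compound 1 to compound 3, the step from compound 2 to compound 4 is expected to be a 1.9-fold lower number from compound 2 to compound 4 (0.28 log units; within the scatter). The number for compound 4 is accordingly estimated at 4000 nM, with a range expected from 2000 nM to 8500 nM.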

Compound 4, half-maximal cytotoxic concentration: 8500 nM
Compound 4: the middle estimate sits 2.1-fold (0.33 log units) below what was measured; low and high end bracket the measured number.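

In this assay, iodo in place of fluoro on an aromatic carbon, here meta to a large group and para to a hydroxy group, gives a 1.1-fold higher number from compound 2 to compound 4 (0.04 log units; within the scatter), so on this core the exchange leaves no change that can be claimed. The earlier step on the other core lay beyond the scatter and this one lies within it, yet the two cannot be told apart: the same change on two cores in this assay, a 2.2-fold lower number (0.33 log units; beyond the scatter) from compound 1 to compound 3 and a 1.1-fold higher number (0.04 log units; within the scatter) from compound 2 to compound 4, 2.4-fold (0.38 log units) apart, within the scatter of two such steps

Going by these compounds alone, this shows that the readings are compatible with one shared modest effect of the exchange, or with none, but it does not show that the change carries over reliably from one core to another, nor that it depends on the core, and with only two pairs the place of the exchange and the rest of the core cannot be separated.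

All four compounds shown carry only halogens as the varied groups, so it stays open how this assay would respond to an amine, a carboxylic acid or a longer chain at the place para to the hydroxy group. Going by these compounds, it also stays open whether the exchange of fluoro for iodo would give a consistent step on further cores of this series.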